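The source may hold more compounds than are shown below. What is called first, only, known or untested is meant among the compounds shown, and "the series" means these compounds.

Compound 1 `COc1ccc(C(=O)/C(=C/c2ccccc2F)COC(C)=O)cc1` gives 22500 nM in a functional assay on A549 cells (Homo sapiens) for inhibition, read by XTT assay, with a stated time of 48 h; a higher number here means a weaker inhibitor, a lower number a stronger inhibitor. Compound 2 `CCC(/C=C(\COC(C)=O)C(=O)c1ccc(OC)cc1)CC` gives > 100000 nM in this assay, which is a limit of the assay and not a number. Compound 3 `COc1ccc(C(=O)/C(=C/c2ccccc2F)CCOC(C)=O)cc1` gives > 100000 nM in this assay, likewise a limit rather than a number.

Compound 3 therefore stands at the weak end of the three values shown, with no measured number of its own. It shares that position with one other value, as the limit of > 100000 nM in this assay, at which 2 of the 3 values shown sit, records. Compound 4 `COc1ccc(C(=O)/C(=C/C2CCCCC2)CCOC(C)=O)cc1` differs from compound 3 by cyclohexyl in place of 2-fluorophenyl on a double-bonded chain carbon bound to a double-bonded chain carbon. The measured step that bears on this change is an at least 4.4-fold higher number from compound 1 to compound 2 (0.64 log units; beyond the scatter), where a saturated group replaced the aromatic one on the same chain carbon and potency fell. That step points toward a weaker compound, while compound 3 already sits at the limit, so any further loss could not be resolved by this assay. Compound 4 is therefore expected to give 150000 nM in this assay, with a range from 50000 nM to 500000 nM. The estimated step that the limit leaves unreadable from compound 3 to compound 4 is expected to remain hidden behind the limit.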

Compound 4, half-maximal inhibitory concentration: > 100000 nM
Compound 4 ended at the assay's limit; the forecaster's own chance of this, stated with the estimate: 85%; the middle value is on the limit's open side.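

Compound 4, like compound 3, gives only a limit in this assay and not a number, so no step can be read between these two compounds: the limit of > 100000 nM in this assay, at which 3 of the 4 values shown sit.

The compounds shown leave open whether cyclohexyl in place of 2-fluorophenyl changes potency at all when the chain carries acetoxymethyl.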